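A Methyl Ortho to the Phenyl Group of Compound 1

The source may report more compounds than this note shows. Statements on the series, on what has been measured and on what is new or still open speak of the compounds shown alone.

Compound 1 `CN1CCCc2ccc(NC(=O)c3ccc(-c4ccccc4)cc3)cc21` is the reference point here. In a functional assay for antagonist activity at transient receptor potential cation channel subfamily V member 1 (Homo sapiens), read by FLIPR and calcium flux (a higher number here means a more potent compound, by a factor of ten per unit of this negative logarithm, a lower number a less potent compound), compound 1 gives 7.5, the highest of the three numbers measured, although each step from it to the other two compounds lies within the scatter. Compound 2 `CN(C)CCN1CCCc2ccc(NC(=O)c3ccc(-c4ccccc4)cc3)cc21`, which carries (dimethylamino)methyl in place of hydrogen on a saturated chain carbon bound to a nitrogen on an aromatic ring in a ring, gives 7.4 in this assay; the step is a number 0.10 log units lower from compound 1 to compound 2 (within the scatter). Compound 3 `CC(=O)N1CCCc2ccc(NC(=O)c3ccc(-c4ccccc4)cc3)cc21`, with acetyl in place of methyl on that nitrogen, gives 7.2, a step of a number 0.30 log units lower from compound 1 to compound 3 (within the scatter). Between the two the step is a number 0.20 log units lower from compound 2 to compound 3 (within the scatter).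

Compound 4 `Cc1cc(C(=O)Nc2ccc3c(c2)N(C)CCC3)ccc1-c1ccccc1` differs from compound 1 by methyl in place of hydrogen on an aromatic carbon. Among the measured compounds shown here, all three measured steps alter only the nitrogen end of the shared core; none touches the aromatic carbon where the methyl enters, so no measured step bears directly on this change. Those steps were all small, and in the absence of any contrary evidence the expectation is a step within the scatter, with a wider range to reflect the uncertainty. Compound 4 is expected to give 7.5 in this assay, with a range from 6.9 to 8.1. This corresponds to an expected step of no change at the digits printed from compound 1 to compound 4 (within the scatter).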

Compound 4, negative logarithm of the antagonist equilibrium constant: 7.4
The estimate for compound 4 lay 0.10 log units above the measured number; measured number inside the range.
By their numbers in this assay, from the lowest: compounds 3, 2, 4 and 1 (each within the scatter of the next).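

Among the compounds shown here, compound 4 is the first compound here to change the end of the molecule far from the ring nitrogen, since the earlier steps all altered the group on that nitrogen. In this assay the step is a number 0.10 log units lower from compound 1 to compound 4 (within the scatter), so methyl can enter on this aromatic carbon, ortho to a phenyl group, without a shift that stands out from repeat-to-repeat variation, and the tolerance seen so far at the nitrogen end now has a counterpart at this carbon, though for one small group only. No measurement here gives a reason for this result.

A single methyl says little about what this carbon accepts in general: an ethyl group, a methoxy group, a chlorine atom, an amine or a carboxylic acid in the same place could each behave differently, and methyl on the other carbons of this ring remains an open question too. As far as these compounds go, it is also open whether the methyl would give a similar result when joined to the acetyl group of compound 3 or the 2-(dimethylamino)ethyl group of compound 2.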